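The compounds below may be only part of what the source reports. "The series", "measured", "known", "first", "only" and "open" are said of these compounds alone.

Measured in a functional assay on U-251 cells (Homo sapiens) for inhibition, read by sulforhodamine B assay, with a stated time of 48 h; on this read-out lower numbers stand for stronger inhibition of growth and higher numbers for weaker inhibition of growth:
- compound 1 `CCOC(=O)c1nn(-c2ccc(Cl)cc2)c(-c2ccc(OC)cc2)c1CNC(C)(C)C`: 431000 nM; > 523000 nM (2 entries) (several entries)
- compound 2 `CC(C)(C)NCc1c(C(=O)O)nn(-c2ccc(Cl)cc2)c1-c1ccc(F)cc1`: > 623000 nM (a limit)
- compound 3 `CC(C)(C)NCc1c(C(=O)O)nn(-c2ccc(Cl)cc2)c1-c1ccc(Cl)cc1`: 518000 nM

Among the measured compounds shown here, compound 3 , at 518000 nM, holds the only single number. Compound 2 gives only a limit, and compound 1 gives several entries.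

Compound 4 `COc1ccc(-c2c(CNC(C)(C)C)c(C(=O)O)nn2-c2ccc(Cl)cc2)cc1` is not yet measured. It differs from compound 3 by methoxy in place of chloro on an aromatic carbon, which is methoxy in place of chloro on an aromatic carbon, para to a large group.

For the measured compounds named here, the one measured exchange at this place is chloro in place of fluoro, an at least 1.2-fold lower number from compound 2 to compound 3 (0.08 log units; that floor lies within the scatter), and it stays within the scatter. Going by the values given here, compound 1 also carries the 4-methoxyphenyl group but differs elsewhere, so it supplies no direct step.

No step beyond the scatter is therefore expected in this assay. The estimated change is a 1.0-fold lower number from compound 3 to compound 4 (0.02 log units; within the scatter). A report of only a limit is also expected to be quite possible. For compound 4 the estimate is 500000 nM, with an expected range of 300000 nM to 750000 nM.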

Compound 4, concentration for 50% growth inhibition: 498000 nM
For compound 4 the middle estimate is 1.0-fold (0.00 log units) above the measured one, within the range that was stated.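

In this assay, among the compounds shown here, the change from 4-chlorophenyl to 4-methoxyphenyl gives a 1.0-fold lower number from compound 3 to compound 4 (0.02 log units; within the scatter) at this position, the first step here with a single number at both ends. Methoxy thus brings a hydrogen-bond acceptor in place of chloro without moving the number beyond the scatter. The comparison with fluoro gives only a floor, an at least 1.2-fold lower number from compound 2 to compound 4 (0.09 log units; that floor lies within the scatter), and it rests on a limit: the limit of > 623000 nM in this assay, at which 1 of the 4 values shown sits.

The groups shown at this position are fluoro, chloro and methoxy, so the outcome with an amine, a hydroxyl or a carboxylic acid there remains open. Also open, going by these compounds, is whether any exchange at this position can move the number in this assay beyond the scatter.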